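Shrinking a Ring: From Oxolane to Oxetane

The source may hold more compounds than are shown below. What is called first, only, known or untested is meant among the compounds shown, and "the series" means these compounds.

Three compounds have been measured in an assay on isolated protein for inhibition of serine/threonine-protein kinase PLK2 (Homo sapiens), read by TR-FRET, with a stated time of 60 min; a higher number here means a weaker inhibitor, a lower number a stronger inhibitor:
- compound 1, `CC[C@@H]1C(=O)N(C)c2cnc(-c3cn[nH]c3-c3ccc(F)cc3F)nc2N1c1cnn(C)c1`: 103 nM
- compound 2, `CC[C@@H]1C(=O)N(C)c2cnc(-n3ccnc3-c3ccccc3)nc2N1[C@@H]1CCOC1`: 21 nM
- compound 3, `CC[C@@H]1C(=O)N(C)c2cnc(-n3ccnc3-c3ccc(F)cc3)nc2N1[C@H]1CCOC1`: 33 nM

Compound 3 sits in the middle of these three numbers. Its value and that of compound 2 lie within the usual scatter of each other, so nothing separates them; compound 1 has a clearly higher number, beyond the scatter, and is therefore the weaker inhibitor of the two.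

Compound 4, `CC[C@@H]1C(=O)N(C)c2cnc(-n3ccnc3-c3ccc(F)cc3)nc2N1C1COC1`, has not been measured. It differs from compound 3 in one place: oxetan-3-yl in place of oxolan-3-yl on a nitrogen on an aromatic ring in a ring. Among the compounds with values here, no measured pair shows this exact change, so there is no step to lean on. A change of one ring member on a group that sits away from the shared core is expected to move the number little in this assay. Compound 4 is therefore estimated at 45 nM, with a range from 20 nM to 110 nM, which is expected to be a step of a 1.4-fold higher number from compound 3 to compound 4 (0.13 log units; within the scatter), not beyond the scatter.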

Compound 4, half-maximal inhibitory concentration: 1040 nM
Estimate against measurement, compound 4: 23-fold (1.36 log units) below; the whole stated range lies below it.
By their numbers in this assay, from the lowest: compounds 2 and 3 (each within the scatter of the next); then compound 1; then compound 4.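

Replacing oxolan-3-yl with oxetan-3-yl gives a 32-fold higher number from compound 3 to compound 4 (1.50 log units; beyond the scatter) and shows that this position, next to the ring atom that bears an ethyl group, can respond sharply to the loss of one ring member. The earlier compounds shown here formed no step and could not reveal this. Nothing available here explains the loss.

Going by these compounds, it remains open how far this sensitivity extends to other groups on this nitrogen. A larger oxan-4-yl ring or an open 2-methoxyethyl chain could show whether the number stays near that of compound 3 or rises as it does for compound 4.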